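Microsomal stability across amine substituent changes on the shared core

The source may report more compounds than this note shows. Statements on the series, on what has been measured and on what is new or still open speak of the compounds shown alone.

compound 1 `COc1cccc(Nc2cc3[nH]c(-c4cccc(C(F)(F)F)c4)nc3cn2)n1`: 45%
compound 2 `COc1ccc(Nc2cc3[nH]c(-c4cccc(C(F)(F)F)c4)nc3cn2)nc1`: 26%

In an ADME assay on microsomes from liver (Homo sapiens) for metabolic stability, read by LC-MS, with a stated time of 30 min, tested at 0.1 uM (on this read-out higher numbers stand for a more stable compound and lower numbers for a less stable compound), compound 2 gives 26%, the lower of the two measured values, while compound 1 gives 45%. Going by the values given here, the only measured step, a number 19 percentage points lower from compound 1 to compound 2 (beyond the scatter), exchanged one methoxypyridinyl group for the other on the same nitrogen. Compound 3 `FC(F)(F)c1cccc(-c2nc3cnc(Nc4cccnn4)cc3[nH]2)c1` differs from compound 2 by pyridazin-3-yl in place of 5-methoxypyridin-2-yl on a nitrogen on an aromatic ring. Among the compounds with values here, no measured step bears directly on removing the methoxy group and changing the ring, so the direction is open. The expected step is within the scatter, a number 4 percentage points higher from compound 2 to compound 3 (within the scatter). For compound 3 the estimate in this assay is 30%, with a range from 12% to 55%.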

Compound 3, percent of the compound remaining: 84%
Compound 3: the middle estimate sits 54 percentage points below what was measured; the whole stated range lies below it.
By their numbers in this assay, from the lowest: compound 2; then compound 1; then compound 3.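

Replacing either methoxypyridinyl group with pyridazin-3-yl in this assay gives a number 58 percentage points higher from compound 2 to compound 3 (beyond the scatter) and a number 39 percentage points higher from compound 1 to compound 3 (beyond the scatter) in the same direction, so this position can carry far higher numbers than the two methoxypyridinyl compounds showed. Both steps remove the methoxy group and change the ring together, and compound 3 stands above both methoxypyridinyl compounds whichever one it is read against. Nothing available explains the rise.

As far as these compounds go, whether the rise follows the loss of the methoxy group or the change of ring stays open. Unsubstituted pyridin-2-yl or a methoxypyridazinyl group on the same nitrogen would separate the two.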